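From hydroxy to 2-aminophenyl on an amide-type nitrogen

The source may hold more compounds than are shown below. What is called first, only, known or untested is meant among the compounds shown, and "the series" means these compounds.

Measured in a functional assay on HCT-116 cells (Homo sapiens) for inhibition, read by CCK-8 assay, with a stated time of 72 h; on this read-out higher numbers stand for weaker inhibition and lower numbers for stronger inhibition:
Compound 1 `Nc1ccccc1NC(=O)c1ccc(CNC(=O)c2n[nH]cc2NC(=O)c2ccccc2)cc1`: 1660 nM
Compound 2 `O=C(NO)c1ccc(CNC(=O)c2n[nH]cc2NC(=O)c2c(Cl)cccc2Cl)cc1`: 500 nM

Compound 2 holds the lower of the two numbers, at 500 nM, and the gap up to compound 1 lies beyond the scatter. The next compound, compound 3 `Nc1ccccc1NC(=O)c1ccc(CNC(=O)c2n[nH]cc2NC(=O)c2c(Cl)cccc2Cl)cc1`, carries 2-aminophenyl in place of hydroxy on an amide-type nitrogen. Among the compounds with values here, no pair of measured compounds shows the size of this change, so any forecast remains tentative. In this assay, a moderate rise in the number, meaning weaker inhibition, is expected, with an estimated step of a 1.8-fold higher number from compound 2 to compound 3 (0.26 log units; within the scatter). Within the data shown here, this expectation leans on compound 1, whose 1660 nM is the only higher number so far. Compound 3 is estimated at 900 nM, with an expected range of 300 nM to 2700 nM.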

Compound 3, half-maximal inhibitory concentration: 710 nM
The estimate for compound 3 lay 1.3-fold (0.10 log units) above the measured number; measured number inside the range.
By their numbers in this assay, from the lowest: compounds 2 and 3 (each within the scatter of the next); then compound 1.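

In this assay, the exchange of hydroxy for 2-aminophenyl on the amide-type nitrogen, with 2,6-dichlorophenyl held in place on the carbonyl carbon, gives a step that does not separate the two groups (a 1.4-fold higher number from compound 2 to compound 3 (0.15 log units; within the scatter)). Within the data shown here, the other change, with 2-aminophenyl held fixed, can now be read for the first time: 2,6-dichlorophenyl in place of phenyl on a carbonyl carbon gives a modest step beyond the scatter (a 2.3-fold lower number from compound 1 to compound 3 (0.37 log units; beyond the scatter)). No measurement on hand explains either step.

As far as these compounds go, it remains open whether the step from phenyl to 2,6-dichlorophenyl has the same size when hydroxy sits on the amide-type nitrogen. From the compounds shown here alone, it is also open how a plain phenyl or a 2-hydroxyphenyl on that nitrogen would read, or a single chlorine or methoxy group on the phenyl ring.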